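A Five-Membered Ring Replaces an Ethyl Chain

The source may report more compounds than this note shows. Statements on the series, on what has been measured and on what is new or still open speak of the compounds shown alone.

Compound 1 `CC(=O)N1CC2CC(C1)N2` and compound 2 `CCCC(=O)N1CC2CC(C1)N2` share one core and differ only in the chain attached to the carbonyl. In an assay on CHO cells for agonist activity at Neuronal acetylcholine receptor; alpha3/alpha6/beta2/beta3 (Homo sapiens), read by FLIPR and calcium flux (on this read-out higher numbers stand for larger maximal responses and lower numbers for smaller maximal responses), compound 1 gives 100%, and in this assay compound 2 gives 92%. For the measured compounds named here, compound 2 therefore holds the lowest of the two numbers, yet the only measured step, a number 8 percentage points lower from compound 1 to compound 2 (within the scatter), lies within the scatter, so the two compounds cannot be told apart on this read-out.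

Compound 3 `O=C(CC1C=CCC1)N1CC2CC(C1)N2` has not yet been measured. It differs from compound 2 as follows: cyclopent-2-en-1-yl in place of ethyl on a saturated chain carbon bound to a carbonyl carbon. The change again alters the group on a saturated chain carbon bound to a carbonyl carbon, the same place that was changed in the measured step, and the cyclopent-2-en-1-yl group brings a five-membered non-aromatic ring of carbon with one double bond outside aromatic rings. Since the measured step of a number 8 percentage points lower from compound 1 to compound 2 (within the scatter) stayed within the scatter, the author expects no step beyond the scatter in this assay, that is a step of about a number 4 percentage points lower from compound 2 to compound 3 (within the scatter). For compound 3 the expected value in this assay is 88%, within a range from 65% to 105%.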

Compound 3, largest response reached (Emax), in percent of the reference or control that the assay uses: 47%
Compound 3: the middle estimate sits 41 percentage points above what was measured; measured number below the stated range.
By their numbers in this assay, from the lowest: compound 3; then compounds 2 and 1 (each within the scatter of the next).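

The place on a saturated chain carbon bound to a carbonyl carbon proved sensitive to its substituent in this assay: cyclopent-2-en-1-yl in place of ethyl gives a number 45 percentage points lower from compound 2 to compound 3 (beyond the scatter) and, in place of hydrogen, gives a number 53 percentage points lower from compound 1 to compound 3 (beyond the scatter) on the same read-out. The earlier pair had shown only a number 8 percentage points lower from compound 1 to compound 2 (within the scatter) for ethyl in place of hydrogen, so it was compound 3 that first showed this position can separate compounds, and its number is the only one set apart from the other two. No measurement shown here bears on why the maximal response drops with this change.

The cyclopent-2-en-1-yl group brings a ring, a double bond outside aromatic rings and more carbon at once, and the compounds shown do not separate these features. From the compounds shown here alone, whether a saturated cyclopentyl ring, a longer open chain such as pentyl, or an amine carried on the same chain would give a number close to those of compound 1 and compound 2 remains open.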